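The source may hold more compounds than are shown below. What is called first, only, known or untested is meant among the compounds shown, and "the series" means these compounds.

Compound 1 `NC(=O)/C=C/c1ccncc1-c1ccc2ccccc2c1` gives > 10000 nM in a functional assay on MCF7 cells (Homo sapiens) for inhibition, read by sulforhodamine B assay, with a stated time of 72 h (a higher number here means a weaker inhibitor of growth, a lower number a stronger inhibitor of growth), which is a limit of the assay rather than a number.
Compound 2 `COC1CN(C(=O)/C=C/c2ccncc2-c2ccc3ccccc3c2)C1` gives > 10000 nM in this assay, again a limit.
Compound 3 `CNC(=O)/C=C/c1ccncc1-c1ccc2c(cnn2C)c1` gives > 10000 nM in this assay, also a limit.

Compound 1 therefore stands only at a limit: nothing shown places it more precisely, and the same holds for compound 2 and compound 3, since (the limit of > 10000 nM in this assay, at which 3 of the 3 values shown sit). Within the data shown here, the one step between measured compounds, a step that the two limits leave unreadable from compound 1 to compound 2, cannot be read for size or direction, because both of its ends are limits.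

The next compound, compound 4 `CNC(=O)CCc1ccncc1-c1ccc2ccccc2c1`, differs from compound 1 in a single place: 2-(methylcarbamoyl)ethyl in place of 2-carbamoylethenyl on an aromatic carbon. No measured step touches this change, and the only step shown gives no readable size, so nothing measured points to a gain or a loss of growth inhibition here. Among the measured compounds shown here, with every value so far sitting at the limit, the most that can be expected is that compound 4 behaves like its neighbours.

Compound 4 is therefore estimated in this assay at 12000 nM, with a range from 3000 nM to 50000 nM, and the step that the limit leaves unreadable from compound 1 to compound 4 is expected to be no larger than the scatter, with the result most likely reported once more as a limit.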

Compound 4, concentration for 50% growth inhibition: > 10000 nM
Compound 4 was reported as a limit (the forecaster's own chance of this, stated with the estimate: 75%); the middle value does not contradict the limit.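

Among these compounds, compound 4 also sits at a limit, so the step from compound 1 to compound 4, like the one from compound 1 to compound 2, cannot be read for size or direction: the limit of > 10000 nM in this assay, at which 4 of the 4 values shown sit.

The compounds shown leave open which change to the shared core, if any, would give a measured number rather than a limit in this assay for growth inhibition.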